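Moving a methyl group: 2,5-dimethylphenyl in place of 3,5-dimethylphenyl

The compounds below may be only part of what the source reports. "The series", "measured", "known", "first", "only" and "open" are said of these compounds alone.

Measured in a functional assay on HT-1080 cells (Homo sapiens) for antiproliferative activity, read by sulforhodamine B assay, with a stated time of 48 h (on this read-out lower numbers stand for stronger inhibition and higher numbers for weaker inhibition), so far:
- compound 1 `CCc1cccc(NS(=O)(=O)c2ccc(N3CCNC3=O)cc2)c1` gives 200 nM in this series
- compound 2 `Cc1cc(C)cc(NS(=O)(=O)c2ccc(N3CCNC3=O)cc2)c1` gives 150 nM in this series

Compound 2 at 150 nM cannot be told apart from compound 1 on these two numbers. Among the compounds with values here, the only measured step is a 1.3-fold lower number from compound 1 to compound 2 (0.12 log units; within the scatter) and it stays within the scatter. Next comes compound 3 `Cc1ccc(C)c(NS(=O)(=O)c2ccc(N3CCNC3=O)cc2)c1` which has the same atoms as compound 2, joined differently. Here 2,5-dimethylphenyl stands in place of 3,5-dimethylphenyl on a sulfonamide nitrogen 2,5-dimethylphenyl in place of 3,5-dimethylphenyl on a sulfonamide nitrogen while the shared core stays untouched.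

Within the data shown here, the one measured step bears on this change only loosely. Among the measured compounds shown here, it exchanged 3-ethylphenyl for 3,5-dimethylphenyl, and no measured compound carries the 2,5-dimethylphenyl group. The evidence therefore gives no ground for a shift in this assay beyond the scatter, though the range has to stay wide. The expected size is a 1.5-fold higher number from compound 2 to compound 3 (0.17 log units; within the scatter) and this estimate is no real departure from compound 2. Compound 3 is expected at 220 nM with an estimated range from 70 nM to 700 nM on this read-out.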

Compound 3, half-maximal inhibitory concentration: 65 nM
For compound 3 the middle estimate is 3.4-fold (0.53 log units) above the measured one, and the stated range ends above it.
By their numbers in this assay, from the lowest: compound 3; then compounds 2 and 1 (each within the scatter of the next).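

In this assay, moving a single methyl group gives a 2.3-fold lower number from compound 2 to compound 3 (0.36 log units; beyond the scatter), with the atom count unchanged and the shared core untouched, so the arrangement of the two methyl groups on the aromatic ring carried by the sulfonamide nitrogen matters at this place in the series. The earlier step, a 1.3-fold lower number from compound 1 to compound 2 (0.12 log units; within the scatter), gave no such reading, since it stayed within the scatter. Set against the 3-ethylphenyl group, the 2,5-dimethylphenyl group gives a 3.1-fold lower number from compound 1 to compound 3 (0.49 log units; beyond the scatter), which makes compound 3 the most potent of the three on this read-out, and nothing at hand accounts for the effect of this rearrangement.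

Still open, going by these compounds, is whether the lower number depends on both methyl groups of the 2,5-dimethylphenyl group or on only one of them, which a 2-methylphenyl or a 3-methylphenyl group on the sulfonamide nitrogen would help to separate. On these data alone, it is equally open whether a 2,5-dimethoxyphenyl, 2,5-dichlorophenyl or 2,5-diethylphenyl group in the same place would match or go beyond compound 3 at 65 nM.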